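A few compounds are considered here, and "the series" means these few. Any claim that something is new, unique, unknown or untested is made for them only; others in the source may bear on it.

Measured compounds:
Compound 1, `N#Cc1c(Nc2ccc(Cl)cc2)nc(SCc2cn(Cc3ccccc3Cl)nn2)nc1-c1ccccc1`: 6520 nM
Compound 2, `N#Cc1c(Nc2ccccc2F)nc(SCc2cn(Cc3ccccc3Cl)nn2)nc1-c1ccccc1`: 8060 nM

Both compounds share one core and differ only in the aryl group on the ring nitrogen. In a functional assay on MCF7 cells (Homo sapiens) for inhibition, read by MTT assay, with a stated time of 72 h (on this read-out higher numbers stand for weaker inhibition and lower numbers for stronger inhibition), compound 1 gives 6520 nM, and in the same assay compound 2 gives 8060 nM. Of the two numbers, compound 2's is the one at the top, with compound 1 the nearest neighbour at a step of a 1.2-fold higher number from compound 1 to compound 2 (0.09 log units; within the scatter); the two are therefore not separated by more than the usual scatter.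

Compound 3, `Cc1ccccc1Nc1nc(SCc2cn(Cc3ccccc3Cl)nn2)nc(-c2ccccc2)c1C#N`, is not yet measured. It differs from compound 2 by methyl in place of fluoro on an aromatic carbon. Among the compounds with values here, the only measured step that bears on it is the change of aryl group from compound 1 to compound 2, which gave a 1.2-fold higher number from compound 1 to compound 2 (0.09 log units; within the scatter). That step also altered the substituent on this same phenyl ring and left the number essentially unchanged. On that basis the change from compound 2 to compound 3 is expected to give a 1.1-fold lower number from compound 2 to compound 3 (0.03 log units; within the scatter), with no shift beyond the scatter. Compound 3 is accordingly estimated at 7500 nM, within a range from 3500 nM to 16000 nM.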

Compound 3, half-maximal inhibitory concentration: 7950 nM
Compound 3: the middle estimate sits 1.1-fold (0.03 log units) below what was measured; the measured number falls inside the stated range.
By their numbers in this assay, from the lowest: compounds 1, 3 and 2 (each within the scatter of the next).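

In this assay, methyl in place of fluoro on an aromatic carbon, ortho to a large group, is the first change shown at this single place on the ring, and it gives a 1.0-fold lower number from compound 2 to compound 3 (0.01 log units; within the scatter). The wider change of 2-methylphenyl in place of 4-chlorophenyl on the nitrogen gives a 1.2-fold higher number from compound 1 to compound 3 (0.09 log units; within the scatter), so compound 1, compound 2 and compound 3 all lie within the scatter of one another, and the fluoro and methyl forms of this ring cannot be told apart on this read-out. Nothing available here accounts for how closely these numbers agree.

The compounds shown leave open whether an amine, a carboxylic acid or a longer chain such as butyl, in place of fluoro or methyl at this same place, would move the number beyond the scatter. They also leave open what a change elsewhere on the shared core would do, since the nitrile, the sulfur-linked side chain and the phenyl group stay the same in all three.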